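Amide side chain change on the shared core

A few compounds are considered here, and "the series" means these few. Any claim that something is new, unique, unknown or untested is made for them only; others in the source may bear on it.

Within the data shown here, in a physicochemical assay for lipophilicity, read by HPLC, at pH 7.5 (a higher number here means a more lipophilic compound, a lower number a more polar compound), compound 1 (`CC[C@H](Nc1c(C#N)c(-c2ccc(Br)cc2)nc2cnccc12)C(N)=O`) gives 2.3, the lower of the two numbers so far. Compound 2 (`CC[C@@H](Nc1c(C#N)c(-c2ccc(-c3ccccc3N(C)C)cc2)nc2cnccc12)C(N)=O`) gives 3.2, and this gap lies beyond the scatter. The two compounds differ in more than one place, so the gap does not isolate any single change.

Compound 3 (`CN(CC(N)=O)c1c(C#N)c(-c2ccc(Br)cc2)nc2cnccc12`) has not yet been measured. Relative to compound 1, it carries (carbamoylmethyl)(methyl)amino in place of (1-carbamoylpropyl)amino on an aromatic carbon, ortho to a cyano group: (carbamoylmethyl)(methyl)amino in place of (1-carbamoylpropyl)amino on an aromatic carbon. Among the measured compounds shown here, no measured pair shows this change, so the expectation rests on compound 1 at 2.3 and on the structural comparison alone. The expected step of a number 0.10 log units lower from compound 1 to compound 3 (within the scatter) in this assay is slightly downward and no larger than the scatter. Compound 3 is estimated at 2.2, with an expected range of 1.8 to 2.6.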

Compound 3, distribution coefficient: 2.1
Estimate against measurement, compound 3: 0.10 log units above; the measured number falls inside the stated range.
By their numbers in this assay, from the lowest: compounds 3 and 1 (each within the scatter of the next); then compound 2.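

Among these compounds, this is the first step read at this position, on the aromatic carbon ortho to a cyano group and opposite the ring nitrogen. In this assay the exchange of (1-carbamoylpropyl)amino for (carbamoylmethyl)(methyl)amino, with the 4-bromophenyl group kept, gives a number 0.20 log units lower from compound 1 to compound 3 (within the scatter) so that this pair cannot be told apart in this read-out, even though the entering group has one heavy atom fewer, a methyl on the attached nitrogen and no defined stereocentre. Nothing measured here speaks to why the step has this size.

As far as these compounds go, whether the same exchange holds on the aryl group carried by compound 2 remains open. Also open, from the compounds shown here alone, is how a carboxylic acid, a primary amine or a longer chain would read at this position on the shared core.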